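From Chloro to Bromo: Expecting Compound 4

This account rests on a few compounds, and the source may have more. Where it says the series, first, only, none or still open, it means among the compounds named here.

Of the compounds shown here, three that share one core have been measured in an assay on isolated protein for inhibition of Amine oxidase [flavin-containing] A (Homo sapiens), read by fluorescence and spectrophotometry, with a stated time of 20 min; a lower number here means a stronger inhibitor, a higher number a weaker inhibitor. Compound 1 `O=C1CSc2cc(OCCCc3ccccc3)ccc2N1` gives 96800 nM. In this assay compound 2 `COc1ccc2c(c1)SCC(=O)N2` gives 21100 nM, and compound 3 `O=C1CSc2cc(OCc3ccc(Cl)cc3)ccc2N1` gives 24400 nM. Among these three numbers compound 3 stands second highest. Its nearest neighbour is compound 2, whose number is lower by an amount within the usual scatter, so the two cannot be told apart. Compound 1 lies further off with a higher number, and that gap is beyond the scatter.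

Compound 4 `O=C1CSc2cc(OCc3ccc(Br)cc3)ccc2N1` has not yet been measured. It differs from compound 3 in one place only: bromo in place of chloro on an aromatic carbon. Within the data shown here, no step between two measured compounds shows what such an exchange does on this core, so the expectation rests on the exchange itself, one heavy atom for one heavy atom with no change in donors, acceptors or charge. The step of a 1.1-fold lower number from compound 3 to compound 4 (0.04 log units; within the scatter) is expected to stay within the scatter, with no clear direction. Compound 4 is therefore estimated at 22000 nM, with a range from 8000 nM to 60000 nM.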

Compound 4, half-maximal inhibitory concentration: 15600 nM
Compound 4: the middle estimate sits 1.4-fold (0.15 log units) above what was measured; the measured number falls inside the stated range.
By their numbers in this assay, from the lowest: compounds 4, 2 and 3 (each within the scatter of the next); then compound 1.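

Among these compounds, this is the first step on the shared core that can be read directly: with bromo in place of chloro on an aromatic carbon, para to a large group, this assay shows a 1.6-fold lower number from compound 3 to compound 4 (0.19 log units; within the scatter). At this place, then, one halogen can stand in for the other without a difference this assay can resolve, and compound 3 and compound 4 cannot be told apart. Nothing measured here accounts for how the two halogens read in this assay.

The compounds shown leave open what a fluoro, an amine or a carboxylic acid would do at this same place, where only two halogens are seen so far. They also leave open whether bromo and chloro would still read alike with a longer chain carrying the halogen-bearing ring.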